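A few compounds are considered here, and "the series" means these few. Any claim that something is new, unique, unknown or untested is made for them only; others in the source may bear on it.

Measured in a toxicity assay on NIH3T3 cells (Mus musculus) for cytotoxicity, read by resazurin assay (on this read-out higher numbers stand for an effect only at larger amounts of compound and lower numbers for an effect already at smaller amounts), so far
- compound 1 `Nc1cc(-c2ccccc2)ccc1Cn1cncc1CNc1ccc(Cl)c(-c2ccccc2)c1` gives > 1000 nM (a limit, not a number)
- compound 2 `N#Cc1ccc(NCc2cncn2Cc2ccc(-c3ccccc3)cc2N)cc1-c1ccccc1` gives > 1000 nM (a limit, not a number)

Compound 2 stands at the limit of > 1000 nM in this assay, at which 2 of the 2 values shown sit, and so has no number. Compound 3 `Nc1cc(-c2ccccc2)ccc1Cn1cncc1CNc1ccc(-c2cncs2)c(-c2ccccc2)c1` follows with the change 1,3-thiazol-5-yl in place of cyano on an aromatic carbon. For the measured compounds named here, the one measured step at this place is a step that the two limits leave unreadable from compound 1 to compound 2 and it offers no size. In this assay no direction can be foreseen, and no step beyond the scatter is expected. The estimated step is a step that the limit leaves unreadable from compound 2 to compound 3 and it remains an expectation. Estimated for compound 3 is 1200 nM with an expected range from 400 nM to 4000 nM and a report at the limit is the likeliest outcome.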

Compound 3, half-maximal effective concentration: > 1000 nM
Compound 3: a limit, no number (the forecaster's own chance of this, stated with the estimate: 70%); the middle value lies beyond the limit too.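

In this assay compound 1, compound 2 and compound 3 all sit at a limit, not a number, so no step among them can be read: the limit of > 1000 nM in this assay, at which 3 of the 3 values shown sit.

The compounds shown leave open whether chloro, cyano or 1,3-thiazol-5-yl on this aromatic carbon makes any difference in this assay.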